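The source may hold more compounds than are shown below. What is called first, only, known or untested is meant among the compounds shown, and "the series" means these compounds.

Compound 1 `CCCCCCCCc1cc2cn(COCCO)c(O)nc-2n1`: 80000 nM
Compound 2 `OCCOCn1cc2ccnc-2nc1O`: > 400000 nM

The account follows the step from compound 2 to compound 3. In a functional assay on HEL cells (Homo sapiens), read by microscopy (a lower number here means that less compound is tolerated, a higher number that more compound is tolerated), compound 2 gives > 400000 nM, which is a limit of the assay and not a number. Of the two values shown, one sits at the limit of > 400000 nM in this assay, at which 1 of the 2 values shown sits. Compound 1, which carries an octyl chain on the same core, gives in this assay a measured number, 80000 nM. Compound 3 `CCCCCCc1cc2cn(COCCO)c(O)nc-2n1` has not yet been measured in this assay. It differs from compound 2 in one place: hexyl in place of hydrogen on an aromatic carbon. Going by the values given here, no measured step is at hand for this change, so the expectation rests on compound 1 alone, and because compound 1 gives 80000 nM a hexyl chain is expected to bring compound 3 to a measured number as well. The step expected from compound 2 to compound 3 is an at least 2.5-fold lower number from compound 2 to compound 3 (0.39 log units; beyond the scatter), downward and beyond the scatter. Compound 3 is estimated at 160000 nM, within 60000 nM to 400000 nM.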

Compound 3, minimum cytotoxic concentration: > 400000 nM
Compound 3: no number, only a limit (the forecaster's own chance of this, stated with the estimate: 30%); middle value at least 2.5-fold (0.39 log units) from the limit.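

In this assay compound 3 gives > 400000 nM, which is a limit of the assay and not a number. Hexyl in place of hydrogen on this aromatic carbon thus does not bring the core to a measured number, and the step between compound 2 and compound 3 cannot be read, both values being limits. Going from the octyl chain to the hexyl chain at this position does register, as an at least 5.0-fold higher number from compound 1 to compound 3 (0.69 log units; beyond the scatter), so the length of the chain here separates a measured number from a limit: the limit of > 400000 nM in this assay, at which 2 of the 3 values shown sit.

The compounds shown leave open how far compound 3 lies beyond its limit, and so how much the hexyl chain itself changes. They also leave open whether a chain longer than octyl, or an amine at the end of the chain, would give a lower number in this assay.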